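Compound 4 from compound 2: moving the chlorine on the chlorophenyl

This account rests on a few compounds, and the source may have more. Where it says the series, first, only, none or still open, it means among the compounds named here.

Measured in a functional assay on the whole organism (strain Swiss) with Mus musculus as the target, in the maximal electroshock model, with a stated time of 0.5 h, at a dose of 300 mg/kg by the intraperitoneal route; on this read-out lower numbers stand for a weaker effect and higher numbers for a stronger effect at the one dose given: compound 1 `CCC(C(=O)N1CCN(c2ccc(Cl)cc2)CC1)N1C(=O)CCC1=O` gives 0%; compound 2 `CC(C(=O)N1CCN(c2ccc(Cl)cc2)CC1)N1C(=O)CCC1=O` gives 100%; compound 3 `CCC(C(=O)N1CCN(c2cccc(F)c2)CC1)N1C(=O)CCC1=O` gives 100%.

Compound 2 stands level with compound 3 at the top of the three, and far from compound 1, as a number 100 percentage points higher from compound 1 to compound 2 (beyond the scatter) shows. Compound 4 `CC(C(=O)N1CCN(c2ccccc2Cl)CC1)N1C(=O)CCC1=O` differs from compound 2 by 2-chlorophenyl in place of 4-chlorophenyl on an amine nitrogen in a ring. Within the data shown here, the only measured step touching the aryl group is a number 100 percentage points higher from compound 1 to compound 3 (beyond the scatter), large, but it starts from a compound at zero and changes halogen and ring position together; no step moves the chlorine within the methyl-bearing series. Compound 2 is already at the ceiling of this read-out, so no rise is possible and a fall cannot be ruled out. For compound 4 the expected value is 80%, range 30% to 100%, meaning an expected step of a number 20 percentage points lower from compound 2 to compound 4 (beyond the scatter).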

Compound 4, a percentage reported as activity, at one dose (the size of the read-out at that dose, not a potency): 0%
Estimate against measurement, compound 4: 80 percentage points above; measured number outside the range, below it.
By their numbers in this assay, from the lowest: compounds 1 and 4 (each within the scatter of the next); then compounds 2 and 3 (each within the scatter of the next).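

In this assay, 2-chlorophenyl in place of 4-chlorophenyl gives a number 100 percentage points lower from compound 2 to compound 4 (beyond the scatter), so with the same atoms in the group, the place of the chlorine alone separates full effect from none at this dose. The earlier aryl step, a number 100 percentage points higher from compound 1 to compound 3 (beyond the scatter), changed halogen and ring position together and could not show this. Nothing available here explains the loss.

From the compounds shown here alone, whether an unsubstituted phenyl or a pyridine ring on this amine nitrogen keeps the effect stays open. So does whether compound 4 shows any effect at another dose or time.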